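The compounds below may be only part of what the source reports. "The series", "measured", "known", "first", "only" and "open" are said of these compounds alone.

Working notes on the series.

Compound 1, `Fc1cccc(F)c1C#Cc1cnc2ccccc2c1`, is the reference point of this pair. Going by the values given here, in a functional assay on LS174T cells (Homo sapiens) for inhibition, with a stated time of 4 days, tested at 1 uM (on this read-out higher numbers stand for a stronger effect at the one concentration tested and lower numbers for a weaker effect), compound 1 gives 41.7%, which is the lower of the two numbers measured so far. Among the compounds with values here, the only other measured compound, compound 2, `Fc1cccc(F)c1C#Cc1cnc2ccccc2c1Cl`, gives 51.5% in this assay. Within the data shown here, the single measured step, chloro in place of hydrogen on an aromatic carbon, amounts to a number 9.8 percentage points higher from compound 1 to compound 2 (within the scatter) and stays within the scatter.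

The next compound, compound 3, `Fc1cccc(F)c1C#Cc1cnc2c(F)cccc2c1`, differs from compound 1 by fluoro in place of hydrogen on an aromatic carbon. Among the measured compounds shown here, no measured step places a fluoro at this position, so the only guidance is the chloro step, which itself did not move the read-out beyond the scatter. A substituent change of this kind on the same core is therefore expected to leave the read-out in this assay close to where compound 1 stands, with no step beyond the scatter in either direction.

The expected step from compound 1 to compound 3 in this assay is a number 3.3 percentage points higher from compound 1 to compound 3 (within the scatter). Compound 3 is therefore estimated at 45% in this assay, with a range from 28% to 62%.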

Compound 3, a percentage reported as inhibition, at one concentration (the size of the read-out at that concentration, not a potency): 63.6%
Compound 3: middle estimate off by 18.6 percentage points, on the low side; measured number outside the range, above it.
By their numbers in this assay, from the lowest: compounds 1 and 2 (each within the scatter of the next); then compound 3.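

In this assay, going by these compounds alone, fluoro in place of hydrogen on an aromatic carbon of the six-membered aromatic ring of carbon only gives a number 21.9 percentage points higher from compound 1 to compound 3 (beyond the scatter) and is the only step so far that lies beyond the scatter, showing that the read-out of the shared core can respond to a change of a single atom at this position. The chloro step (a number 9.8 percentage points higher from compound 1 to compound 2 (within the scatter)) stands at a different place on the core and brings a different group, so the pair of steps cannot separate the effect of the group from the effect of its place. Nothing available accounts for the size of the fluoro step.

From the compounds shown here alone, whether the higher number belongs to fluoro specifically or would also appear with chloro, a methoxy group or an amine at this same position remains open, as does the outcome of fluoro at the place that chloro occupies in compound 2. With one concentration per compound, the series shows only a stronger effect of compound 3 than of compound 1 at that concentration and leaves open how the two compare at any other concentration.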